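Epoxide in Place of a Diene Alcohol Side Chain

This account rests on a few compounds, and the source may have more. Where it says the series, first, only, none or still open, it means among the compounds named here.

Measured so far in a functional assay on SW480 cells (Homo sapiens) for cytotoxicity, read by MTT assay, with a stated time of 48 h; a lower number here means a stronger inhibitor, a higher number a weaker inhibitor:
- compound 1 `C=CC(=C)CC[C@@H]1[C@@]2(C)CCC[C@](C)(COC(=O)/C=C\c3ccc(O)cc3)[C@@H]2CC[C@@]1(C)O` gives 13600 nM
- compound 2 `C=C1CC[C@@H]2[C@](C)(CCC[C@]2(C)C(=O)O)[C@H]1CC/C(C)=C/CO` gives > 40000 nM, which is a limit of the assay rather than a number
- compound 3 `C=CC(=C)[C@@H](O)C[C@H]1C(=C)CC[C@@H]2[C@]1(C)CCC[C@]2(C)C(=O)O` gives > 40000 nM, again only a limit of the assay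

Compound 3 therefore stands at the weak end of what is shown: in this assay it gives no measurable number at all, sharing the limit of > 40000 nM in this assay, at which 2 of the 3 values shown sit, with compound 2. Compound 4 `C=C[C@@]1(C)O[C@H]1C[C@H]1C(=C)CC[C@@H]2[C@]1(C)CCC[C@]2(C)C(=O)O` differs from compound 3 in one place: a group of 6 heavy atoms (5 carbon, 1 oxygen; one three-membered non-aromatic ring with 1 hetero atom) in place of a group of 6 heavy atoms (5 carbon, 1 oxygen; no ring), on a saturated chain carbon bound to a saturated ring carbon

Going by the values given here, the only measured step that touches this side chain is a step that the two limits leave unreadable from compound 2 to compound 3, and since both ends are limits its size cannot be read. Among the compounds with values here, compound 1, with a different core, gives the only real number, and it is still weak. Nothing shown points to a large gain from reshaping the side chain, so compound 4 is expected to remain weak, with a real chance that only a limit is reported again. The step of an at least 1.3-fold lower number from compound 3 to compound 4 (0.12 log units; that floor lies within the scatter) is estimated to lie within the scatter. For compound 4 the estimate in this assay is 30000 nM, ranging from 8000 nM to 80000 nM.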

Compound 4, half-maximal inhibitory concentration: > 40000 nM
Compound 4 was reported as a limit (the forecaster's own chance of this, stated with the estimate: 60%); at least 1.3-fold (0.12 log units) between middle value and limit.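

Compound 4 gives only a limit, as do compound 2 and compound 3, so no step among these three can be read: the limit of > 40000 nM in this assay, at which 3 of the 4 values shown sit. On these data alone, whether their different side chains change cytotoxicity at all, and by how much, remains open.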